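This account rests on a few compounds, and the source may have more. Where it says the series, first, only, none or still open, it means among the compounds named here.

Four compounds share a skeleton in which two carbonyl-bearing chains meet at a central double-bonded carbon, and each one carries methoxy-substituted aromatic rings at its ends. Compound 1 `COc1cc(C=C(C(=O)/C=C/c2cccc(OC)c2OC)C(=O)/C=C/c2cccc(OC)c2OC)cc(OC)c1O` was tested in a functional assay on HepG2 cells (Homo sapiens) for antiproliferative activity, read by sulforhodamine B assay, with a stated time of 48 h (on this read-out lower numbers stand for stronger inhibition and higher numbers for weaker inhibition), where compound 1 gives 210 nM. Compound 2 `COc1ccc(C=C(C(=O)/C=C/c2cccc(OC)c2OC)C(=O)/C=C/c2cccc(OC)c2OC)cc1O` differs from compound 1 in one place: 3-hydroxy-4-methoxyphenyl in place of 4-hydroxy-3,5-dimethoxyphenyl on a double-bonded chain carbon bound to a double-bonded chain carbon. In this assay compound 2 gives 270 nM, and the step of a 1.3-fold higher number from compound 1 to compound 2 (0.11 log units; within the scatter) is small enough to count as noise rather than a real shift.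

Compound 3 `COc1ccc(/C=C/C(=O)C(=Cc2cc(OC)c(O)c(OC)c2)C(=O)/C=C/c2ccc(OC)cc2OC)c(OC)c1` is built from the same atoms as compound 1 but joined differently, and how the two cores differ is not broken down here. In this assay compound 3 gives 320 nM, which sits close to the numbers of compound 1 and compound 2, all within the range that repeated runs of the same measurement would span.

Compound 4 `COc1ccc(/C=C/C(=O)C(=Cc2ccc(OC)c(O)c2)C(=O)/C=C/c2ccc(OC)cc2OC)c(OC)c1` has not yet been measured. It stands to compound 3 exactly as compound 2 stands to compound 1: 3-hydroxy-4-methoxyphenyl in place of 4-hydroxy-3,5-dimethoxyphenyl on a double-bonded chain carbon bound to a double-bonded chain carbon. Within the data shown here, since this is the same change made in the same place, compound 4 is expected to show a step of about a 1.3-fold higher number from compound 3 to compound 4 (0.10 log units; within the scatter), because a 1.3-fold higher number from compound 1 to compound 2 (0.11 log units; within the scatter) is the only precedent for this change. On that basis compound 4 is estimated to give 400 nM in this assay, most likely somewhere between 200 nM and 800 nM.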

Compound 4, half-maximal inhibitory concentration: 390 nM
Estimate against measurement, compound 4: 1.0-fold (0.01 log units) above; the range from low to high includes it.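

In this assay, putting 3-hydroxy-4-methoxyphenyl in place of 4-hydroxy-3,5-dimethoxyphenyl gives a 1.2-fold higher number from compound 3 to compound 4 (0.09 log units; within the scatter), a shift too small to tell apart from the differences expected between repeated runs. Set beside the same change on the core of compound 1, the two results agree: the same change on two cores in this assay, a 1.3-fold higher number (0.11 log units; within the scatter) from compound 1 to compound 2 and a 1.2-fold higher number (0.09 log units; within the scatter) from compound 3 to compound 4, 1.1-fold (0.02 log units) apart, within the scatter of two such steps. This shows that on these two cores the swap behaves alike and leaves the number within the usual noise, but the agreement is between two steps that are each indistinguishable from no change, which makes it a weak test of transfer, and two cores cannot show that the same would hold on a third or that the two groups are interchangeable in general.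

The compounds shown carry only hydroxy and methoxy groups on this aromatic ring, and whether an amine, a carboxylic acid or a chlorine atom there would produce a step beyond the scatter remains open. Also open, on these data alone, is whether the change behaves the same way on a core whose end rings bear a longer chain such as butoxy instead of methoxy, and whether any of this holds outside this assay.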